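Urea in Place of Amide on a Shared Core

The compounds below may be only part of what the source reports. "The series", "measured", "known", "first", "only" and "open" are said of these compounds alone.

Measured compounds:
Compound 1 `O=C(Nc1cccc(-n2cc(-c3ccncc3)c(-c3ccc(Cl)c(O)c3)n2)c1)Nc1cccc(C(F)(F)F)c1` — in a functional assay on MCF7 cells (Homo sapiens) for inhibition, read by sulforhodamine B assay, with a stated time of 48 h (a lower number here means a stronger inhibitor of growth, a higher number a weaker inhibitor of growth), compound 1 gives > 32500 nM, which is a limit of the assay and not a number.
Compound 2 `COc1cc(-c2nn(-c3cccc(NC(=O)c4cccc(C(F)(F)F)c4)c3)cc2-c2ccncc2)ccc1Cl` — in this assay compound 2 gives > 50000 nM, likewise a limit of the assay and not a number.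

Within the data shown here, compound 2 therefore stands nowhere definite on a scale: the only thing known is that its growth-inhibiting concentration sits at the limit (the limit of > 50000 nM in this assay, at which 1 of the 2 values shown sits), and the one other value shown is also a limit (the limit of > 32500 nM in this assay, at which 1 of the 2 values shown sits). Among the measured compounds shown here, neither compound reached total growth inhibition within the range tested, so no step between them can be sized.

Compound 3 `COc1cc(-c2nn(-c3cccc(NC(=O)Nc4ccc(Cl)c(C(F)(F)F)c4)c3)cc2-c2ccncc2)ccc1Cl` keeps the core of compound 2 and changes one place: (4-chloro-3-(trifluoromethyl)phenyl)amino in place of 3-(trifluoromethyl)phenyl on a carbonyl carbon. The new group brings the carbonyl into a urea, as in compound 1, which also sat at a limit. For the measured compounds named here, with both known values at limits and no measured step to lean on, the expected step of an at least 1.1-fold lower number from compound 2 to compound 3 (0.04 log units; that floor lies within the scatter) is none beyond the scatter, and a further limit is the most likely outcome. Compound 3 is estimated at 45000 nM, with a range from 12000 nM to 120000 nM.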

Compound 3, concentration for total growth inhibition: > 32500 nM
Compound 3: a limit, no number; the forecaster's own chance of this, stated with the estimate: 70%; the middle value does not contradict the limit.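

No step can be read between compound 2 and compound 3, because each gives a limit of the assay and not a number: the limit of > 32500 nM in this assay, at which 2 of the 3 values shown sit.

The limit of compound 2 is a different one: the limit of > 50000 nM in this assay, at which 1 of the 3 values shown sits.

The compounds shown leave open whether any of them, urea or amide, reaches total growth inhibition at a measurable concentration in this assay.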